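Swapping ethyl for ethoxy on a carbonyl carbon

The compounds below may be only part of what the source reports. "The series", "measured", "known", "first", "only" and "open" are said of these compounds alone.

Of the compounds shown here, three have so far been measured in a physicochemical assay for solubility, read by HPLC, in phosphate buffer, measured as kinetic solubility, at pH 7.4 (on this read-out higher numbers stand for higher solubility and lower numbers for lower solubility), and they give a narrow spread of numbers. Compound 1 `Cc1c(C(=O)O)cc(-c2cccc(Cl)c2)n1-c1ccc(S(N)(=O)=O)cc1` reads 100000 nM and compound 2 `CCC(=O)c1cc(-c2ccc(F)cc2)n(-c2ccc(S(N)(=O)=O)cc2)n1` reads 88900 nM on this scale, two numbers within the usual scatter of each other. Compound 3 `CCC(=O)c1cc(-c2ccc(Cl)cc2)n(-c2ccc(S(N)(=O)=O)cc2)n1` reads 37800 nM as the lowest number of the three.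

Compound 4 `CCOC(=O)c1cc(-c2ccc(Cl)cc2)n(-c2ccc(S(N)(=O)=O)cc2)n1` has not been measured yet. It differs from compound 3 by a single swap of ethoxy in place of ethyl on a carbonyl carbon, which turns propanoyl into ethoxycarbonyl.

For the measured compounds named here, no measured pair carries this swap. Going by the values given here, the only measured step is a different one, chloro in place of fluoro on an aromatic carbon, and it gave a 2.4-fold lower number from compound 2 to compound 3 (0.37 log units; beyond the scatter) as a modest move. That step offers a sense of scale and nothing more about direction. A small move is therefore expected in this assay with a 1.3-fold lower number from compound 3 to compound 4 (0.10 log units; within the scatter) estimated to stay within the usual scatter. For compound 4 the estimated value is 30000 nM with an expected range from 10000 nM to 80000 nM on this scale.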

Compound 4, solubility: 53300 nM
Compound 4: middle estimate off by 1.8-fold (0.25 log units), on the low side; the measured number falls inside the stated range.
By their numbers in this assay, from the lowest: compounds 3, 4, 2 and 1 (each within the scatter of the next, the first and the last beyond it).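

In this assay, replacing ethyl with ethoxy on a carbonyl carbon, which turns propanoyl into ethoxycarbonyl, gives a 1.4-fold higher number from compound 3 to compound 4 (0.15 log units; within the scatter) and so leaves the two compounds indistinguishable on this read-out. For the compounds shown here, this is the first look at this position: the earlier step, a 2.4-fold lower number from compound 2 to compound 3 (0.37 log units; beyond the scatter), was made on an aromatic carbon and lies beyond the scatter, whereas here the entering ethoxy adds an oxygen and a hydrogen-bond acceptor that ethyl lacks, without a move beyond the scatter. Nothing measured here explains why this swap leaves the number within the scatter.

Going by these compounds alone, the swap has been seen only with the chloro group present, so it remains open whether it would read the same with the fluoro group of compound 2. Also open, from the compounds shown here alone, is how the number would respond to a larger departure on the same carbonyl carbon, such as an amine in place of ethoxy, a carboxylic acid, or a longer chain than ethyl.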